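Morpholinyl to Thiomorpholinyl: an Expected Solubility Step

The compounds below may be only part of what the source reports. "The series", "measured", "known", "first", "only" and "open" are said of these compounds alone.

Three compounds share one core and differ only in the group on the carbonyl carbon. Compound 1 `CC(C)(C)c1cc(NC(=O)[C@@H]2CCCCN2C(=O)c2ccccc2)no1` carries a phenyl there, and in a physicochemical assay for solubility, read by HPLC, at pH 6.8 (on this read-out lower numbers stand for lower solubility and higher numbers for higher solubility), compound 1 gives 0.9 ug/mL. Compound 2 `CC(C)(C)c1cc(NC(=O)[C@@H]2CCCCN2C(=O)C2CCOCC2)no1` gives 48 ug/mL, and compound 3 `CC(C)(C)c1cc(NC(=O)[C@@H]2CCCCN2C(=O)N2CCOCC2)no1` gives 45 ug/mL. The two measured steps away from compound 1 were large: a 53-fold higher number from compound 1 to compound 2 (1.73 log units; beyond the scatter) and a 50-fold higher number from compound 1 to compound 3 (1.70 log units; beyond the scatter). Between the two ring-bearing analogues the change was small: a 1.1-fold lower number from compound 2 to compound 3 (0.03 log units; within the scatter). Compound 3 thus stands second highest of the three, close to compound 2 and far from compound 1.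

Compound 4 `CC(C)(C)c1cc(NC(=O)[C@@H]2CCCCN2C(=O)N2CCSCC2)no1` differs from compound 3 in one place: thiomorpholin-4-yl in place of morpholin-4-yl on a carbonyl carbon. Going by the values given here, no measured step exchanges an oxygen-containing ring for a sulfur-containing one, so the nearest guide is the small step between compound 2 and compound 3. The author therefore expects for compound 4 a step of a 2.3-fold lower number from compound 3 to compound 4 (0.35 log units; beyond the scatter), a modest drop that may not exceed the scatter. His estimate for compound 4 is 20 ug/mL, within a range from 6 ug/mL to 55 ug/mL.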

Compound 4, solubility: 46 ug/mL
Beside the measured number, compound 4's estimate is 2.3-fold (0.36 log units) below it; measured number inside the range.
By their numbers in this assay, from the lowest: compound 1; then compounds 3, 4 and 2 (each within the scatter of the next).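

Swapping the ring oxygen of morpholin-4-yl for the sulfur of thiomorpholin-4-yl on this carbonyl carbon, an exchange no earlier pair covered, gave no difference that can be told apart in this assay (a 1.0-fold higher number from compound 3 to compound 4 (0.01 log units; within the scatter)). The oxan-4-yl group is likewise not separated from thiomorpholin-4-yl (a 1.0-fold lower number from compound 2 to compound 4 (0.02 log units; within the scatter)), while the step from phenyl is large (a 51-fold higher number from compound 1 to compound 4 (1.71 log units; beyond the scatter)), so among these four compounds the three six-membered non-aromatic rings read alike and only the phenyl stands apart. Nothing available here accounts for this result.

Open, on these data alone, is whether a piperazin-1-yl ring, a ring carrying a carboxylic acid or an open-chain dimethylamino group on this carbonyl carbon would read like these three rings. Also open, as far as these compounds go, is how the sulfone of the thiomorpholin-4-yl ring would compare.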